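The source may hold more compounds than are shown below. What is called first, only, known or untested is meant among the compounds shown, and "the series" means these compounds.

In a toxicity assay on cells (Macrophage, Mus musculus, strain BALB/c) for cytotoxicity, read by MTT assay (on this read-out higher numbers stand for weaker inhibition and lower numbers for stronger inhibition), compound 1 `C=CCOc1cc(OC)c(C(=O)/C=C/c2ccc(OC)cc2)c(OCC=C)c1` gives 18700 nM. Compound 2 `C=CCOc1cc(OC)c(C(=O)/C=C/c2ccncc2)c(OCC=C)c1` has no number to place it in the series, its entry being "not determined" (no result reported). Compound 3 `C=CCOc1cc(OC)c(C(=O)/C=C/c2ccc(Cl)cc2)c(OCC=C)c1` carries 4-chlorophenyl in place of pyridin-4-yl on a double-bonded chain carbon bound to a double-bonded chain carbon. Among the compounds with values here, without a measured starting point, this change cannot be sized directly, so the expectation rests on the only number available, from compound 1 at 18700 nM. No shift beyond the scatter from that value is expected. In this assay the estimate for compound 3 is 16000 nM, with an expected range of 6000 nM to 42000 nM.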

Compound 3, half-maximal inhibitory concentration: 13000 nM
Compound 3: the middle estimate sits 1.2-fold (0.09 log units) above what was measured, within the range that was stated.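

In this assay the exchange of methoxy for chloro on an aromatic carbon gives a 1.4-fold lower number from compound 1 to compound 3 (0.16 log units; within the scatter) and so shows that, at this position, the two groups are not told apart by this read-out. The comparison between compound 2 and compound 3 cannot be read, as compound 2 carries no number. No supporting data bear on this result.

Open, from the compounds shown here alone, is whether an amine, a carboxylic acid or a longer chain on that aromatic carbon would give a step beyond the scatter in this assay. Also open, going by these compounds, is where pyridin-4-yl stands against 4-chlorophenyl.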